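Enone-linked bicyclic series: methoxy removal on the benzoyl ring

The compounds below may be only part of what the source reports. "The series", "measured", "known", "first", "only" and "open" are said of these compounds alone.

Measured in a functional assay on DU-145 cells (Homo sapiens) for antiproliferative activity, read by MTT assay, with a stated time of 24 h; a lower number here means a stronger inhibitor, a higher number a weaker inhibitor:
compound 1 `COc1ccc(C(=O)/C=C/c2cc(-c3cc(OC)c(OC)c(OC)c3)n3nc(-c4ccccc4)cc3n2)cc1OC`: 29900 nM
compound 2 `COc1ccc(-c2cc(C(=O)/C=C/c3cc(OC)c(OC)c(OC)c3)nc3cc(-c4ccccc4)nn23)cc1OC`: 14700 nM
compound 3 `COc1ccc(C(=O)/C=C/c2cc(-c3ccc(OC)c(OC)c3)n3nc(-c4ccccc4)cc3n2)cc1`: 14600 nM

All three numbers sit in the same weak region. Compound 3 has the lowest number of the three, but compound 2 lies within the scatter of it, so no order can be read between compound 3 and compound 2. Among the measured compounds shown here, compound 1 stands two steps further up, beyond the scatter, and is the only one that separates from compound 3. For the measured compounds named here, the three compounds differ in more than one place at once, so no single step between measured compounds can be isolated.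

The next compound, compound 4 `COc1ccc(-c2cc(/C=C/C(=O)c3ccccc3)nc3cc(-c4ccccc4)nn23)cc1OC`, is reached from compound 3 by a change in one place: hydrogen in place of methoxy on an aromatic carbon. The change sits on the (4-methoxyphenyl)carbonyl side of the enone, on an aromatic carbon of a six-membered aromatic ring of carbon only, para to a large group, and leaves the rest of the molecule untouched.

Going by the values given here, no measured pair isolates this change, so the expected step from compound 3 to compound 4 is judged from the general spread of the series. Compound 4 is expected to remain in this weak range, with a step of a 1.4-fold higher number from compound 3 to compound 4 (0.14 log units; within the scatter) that is expected to be small, most likely toward a slightly higher number, and possibly none beyond the scatter. The estimate for compound 4 in this assay is 20000 nM, within a range of 7000 nM to 60000 nM.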

Compound 4, half-maximal inhibitory concentration: 10000 nM
The estimate for compound 4 lay 2.0-fold (0.30 log units) above the measured number; measured number inside the range.
By their numbers in this assay, from the lowest: compounds 4, 3 and 2 (each within the scatter of the next); then compound 1.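

The pair gives the series its first step that can be read in one place: with hydrogen in place of methoxy on an aromatic carbon of the (4-methoxyphenyl)carbonyl side, this assay shows a 1.5-fold lower number from compound 3 to compound 4 (0.16 log units; within the scatter). The 2-((4-methoxyphenyl)carbonyl)ethenyl and 2-benzoylethenyl forms therefore cannot be told apart in this read-out, and the methoxy at this place is not needed to hold the number in its present region. Removing it also opens no route out of the weak range, so this change alone offers no gain that can be claimed for the series. Nothing available bears on the reason for this result.

Going by these compounds, whether another group at this place, such as an amine, a carboxylic acid or a longer alkoxy chain, would carry the number beyond the scatter remains open. Also open, on these data alone, is whether the same exchange of methoxy for hydrogen on the other methoxy-bearing ring would give a step of similar size, or one that can be separated from the scatter.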